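Bromo for Fluoro on the Sulfonyl Aryl Ring

The source may hold more compounds than are shown below. What is called first, only, known or untested is meant among the compounds shown, and "the series" means these compounds.

Compound 1, `CCN(C/C=C/C#CC(C)(C)C)Cc1cccc(OCCN(C)S(=O)(=O)c2ccsc2)c1`, gives 250 nM in a functional assay on HepG2 cells for inhibition of squalene monooxygenase (Homo sapiens); on this read-out higher numbers stand for weaker inhibition and lower numbers for stronger inhibition.
Compound 2, `CCN(C/C=C/C#CC(C)(C)C)Cc1cccc(OCCN(C)S(=O)(=O)c2ccc(F)cc2)c1`, gives 255 nM in this assay.

Compound 2 and compound 1 give numbers within the scatter of each other, the step being a 1.0-fold higher number from compound 1 to compound 2 (0.01 log units; within the scatter). Compound 3, `CCN(C/C=C/C#CC(C)(C)C)Cc1cccc(OCCN(C)S(=O)(=O)c2ccc(Br)cc2)c1`, differs from compound 2 by bromo in place of fluoro on an aromatic carbon. For the measured compounds named here, no measured step exchanges one halogen for another; the only step known alters the aryl group on the sulfonyl sulfur and lay within the scatter. Compound 3 is therefore expected to move by a 1.2-fold lower number from compound 2 to compound 3 (0.06 log units; within the scatter), with nothing beyond the scatter foreseen. The estimate for compound 3 is 220 nM, ranging from 80 nM to 600 nM.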

Compound 3, half-maximal inhibitory concentration: 330 nM
For compound 3 the middle estimate is 1.5-fold (0.18 log units) below the measured one; the measured number falls inside the stated range.
By their numbers in this assay, from the lowest: compounds 1, 2 and 3 (each within the scatter of the next).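

For the compounds shown here, for the halogen on this six-membered aromatic ring, the earlier compounds offered no measured exchange; here, bromo in place of fluoro gives a 1.3-fold higher number from compound 2 to compound 3 (0.11 log units; within the scatter) in this assay and stays within the scatter. Compared with the thiophen-3-yl group, the 4-bromophenyl group gives a 1.3-fold higher number from compound 1 to compound 3 (0.12 log units; within the scatter) and also stays within the scatter, so all three sulfonyl groups remain indistinguishable on this read-out. No available evidence bears on this result. On these data alone, whether an amine, a carboxylic acid or a methoxy group at this ring position would also stay within the scatter remains open.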